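A removed methoxy group on a glycosylated hydroxycinnamoyl ester

A few compounds are considered here, and "the series" means these few. Any claim that something is new, unique, unknown or untested is made for them only; others in the source may bear on it.

Compound 1, with structure `COc1cc(/C=C/C(=O)O[C@H]2[C@H](OC[C@H]3O[C@@H](Oc4cc5c(cc4O)C[C@@H](C(=O)O)N5C(=O)/C=C/c4ccc(O)c(OC)c4)[C@H](O)[C@@H](O)[C@@H]3O)O[C@H](CO)[C@@H](O)[C@@H]2O)ccc1O`, was examined in a physicochemical assay, with a stated time of 30 min (a lower number here means that less compound is needed, a higher number that more compound is needed for the effect), and in that assay compound 1 gives 27600 nM. Within the data shown here, only one other measured compound accompanies it: compound 2, with structure `COc1cc(/C=C/C(=O)N2c3cc(O[C@@H]4O[C@H](CO[C@@H]5O[C@H](CO)[C@@H](O)[C@H](O)[C@H]5O)[C@@H](O)[C@H](O)[C@H]4O)c(O)cc3C[C@H]2C(=O)O)ccc1O[C@@H]1O[C@H](CO)[C@@H](O)[C@H](O)[C@H]1O`, which in this assay gives 40900 nM. Among the measured compounds shown here, the two numbers lie within the usual scatter of each other, so compound 1 does not stand apart from compound 2 on what has been measured, and no step between compounds differing in a single place has been characterised.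

The next compound, compound 3, with structure `COc1cc(/C=C/C(=O)O[C@H]2[C@H](OC[C@H]3O[C@@H](Oc4cc5c(cc4O)C[C@@H](C(=O)O)N5C(=O)/C=C/c4ccc(O)cc4)[C@H](O)[C@@H](O)[C@@H]3O)O[C@H](CO)[C@@H](O)[C@@H]2O)ccc1O`, differs from compound 1 in one place: hydrogen in place of methoxy on an aromatic carbon. The change is small in heavy-atom count and sits on the outer hydroxycinnamoyl ester rather than on the shared core.

For the measured compounds named here, with no measured step to lean on, the expected step of a 1.1-fold higher number from compound 1 to compound 3 (0.04 log units; within the scatter) is none beyond the scatter, with no clear direction. Compound 3 is therefore estimated to give about 30000 nM in this assay, in a range from 12000 nM to 75000 nM.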

Compound 3, half-maximal effective concentration: 29100 nM
Estimate against measurement, compound 3: 1.0-fold (0.01 log units) above; low and high end bracket the measured number.
By their numbers in this assay, from the lowest: compounds 1, 3 and 2 (each within the scatter of the next).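

In this assay, the change from 4-hydroxy-3-methoxyphenyl to 4-hydroxyphenyl gives the first step characterised between compounds differing in one place, a 1.1-fold higher number from compound 1 to compound 3 (0.02 log units; within the scatter). At this aromatic carbon, ortho to a hydroxy group, the methoxy group and its 2 heavy atoms can therefore give way to hydrogen with no difference beyond the scatter, so the read-out does not depend on this methoxy group in this pair. No measurement is available that could explain this outcome.

The compounds shown leave open whether another group on the same aromatic carbon, such as an ethoxy group, an amine or a carboxylic acid, would also stay within the scatter of compound 1. They also leave open whether the 4-hydroxy-3-methoxyphenyl group that compound 3 still carries would tolerate the same replacement, and whether replacing both methoxy groups with hydrogen would give a step of similar size.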